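The compounds below may be only part of what the source reports. "The series", "measured", "known", "first", "only" and "open" are said of these compounds alone.

In a functional assay on PANC-1 cells (Homo sapiens) for antiproliferative activity, read by MTT assay, with a stated time of 48 h (on this read-out lower numbers stand for stronger inhibition and higher numbers for weaker inhibition), compound 1 (`COc1ccc(-c2c(Nc3ccc(F)cc3)c3ccccc3oc2=O)cc1`) gives 32000 nM. Among the measured compounds shown here, this is the lower of the two numbers measured so far, the other coming from compound 2 (`COc1ccc(-c2c(Nc3ccc(C)cc3)c3ccccc3oc2=O)cc1`) at 66100 nM. For the measured compounds named here, compound 3 (`COc1ccc(-c2c(Nc3ccc(F)cc3)c3ccc(O)cc3oc2=O)cc1`) has no measurement yet. It keeps the core of compound 1 and differs in one place: hydroxy in place of hydrogen on an aromatic carbon. Hydroxy stands in place of hydrogen on an aromatic carbon of a six-membered aromatic ring of carbon only, part of a fused or bridged system of two rings.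

Going by the values given here, only one measured step is available, a 2.1-fold higher number from compound 1 to compound 2 (0.32 log units; beyond the scatter). It is modest, but it replaces fluoro with methyl, so it bears on this change only loosely, as a guide to size. Among the compounds with values here, no measured pair shows what hydroxy in place of hydrogen does here, and either direction remains open. A modest change is expected, leaning slightly towards a lower number. The estimated step is a 1.6-fold lower number from compound 1 to compound 3 (0.20 log units; within the scatter). In this assay the estimated value for compound 3 is 20000 nM, with an expected range from 6000 nM to 60000 nM.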

Compound 3, half-maximal inhibitory concentration: 75100 nM
The estimate for compound 3 lay 3.8-fold (0.57 log units) below the measured number; the measured number lies above the stated range.
By their numbers in this assay, from the lowest: compound 1; then compounds 2 and 3 (each within the scatter of the next).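

Among the compounds shown here, the first measured change on this ring of the core points towards weaker inhibition: in this assay, hydroxy in place of hydrogen gives a 2.3-fold higher number from compound 1 to compound 3 (0.37 log units; beyond the scatter) and so takes the number away from that of compound 1, not below it. This step is modest but beyond the scatter, and it shows that, for this one pair, hydroxy on this aromatic carbon, meta to a fused ring and para to a fused ring, brings no gain in inhibition; the earlier step, a 2.1-fold higher number from compound 1 to compound 2 (0.32 log units; beyond the scatter) in the same direction, replaced fluoro with methyl at a different place and could not show this. No measured evidence here accounts for the loss that comes with the hydroxy group.

The compounds shown leave open whether the rise belongs to hydroxy itself or to any group on this carbon, as a methoxy group, an amine or a chlorine atom there could tell. They also leave open whether hydroxy on another carbon of the same ring would move the number in the same direction, or by a similar amount.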